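The compounds below may be only part of what the source reports. "The series", "measured", "known", "first", "only" and "open" are said of these compounds alone.

Working notes on the series. All three measured compounds were run in a functional assay on NCI-H23 cells (Homo sapiens) for antiproliferative activity, read by XTT assay; on this read-out lower numbers stand for stronger inhibition and higher numbers for weaker inhibition. Compound 1 `CC(C)CCOc1cccc2occ(Cc3coc4ccccc4c3=O)c(=O)c12` carries an isopentyloxy group on its core; in this assay compound 1 gives > 10000 nM, which is a limit of the assay and not a number, as noted in the limit of > 10000 nM in this assay, at which 1 of the 3 values shown sits. Compound 2 `O=c1c(Cc2coc3cccc(OCC4CCCCC4)c3c2=O)coc2cc(O)ccc12` gives 2150 nM in this assay. Compound 3 `O=C1c2c(OCC3CCCCC3)cccc2OCC1Cc1coc2ccccc2c1=O` gives 9490 nM in this assay. Among the compounds with values here, compounds 2 and 3 differ from compound 1 in more than one place, so no single step between measured compounds can be read from these three values; they show only that the measured members sit at weak to very weak inhibition.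

Compound 4 `COc1cccc2occ(Cc3coc4ccccc4c3=O)c(=O)c12` is the next member, not yet measured in this assay. It differs from compound 1 by hydrogen in place of isobutyl on a saturated chain carbon bound to an oxygen on an aromatic ring, so that isopentyloxy becomes methoxy. With compound 1 known only as a limit, no direction for this change can be drawn from the measured values. The step from compound 1 to compound 4 is expected to be a number no higher from compound 1 to compound 4 (the limit leaves the size open), within the usual scatter. For compound 4 the expected value in this assay is 10000 nM, with a range from 3000 nM to 30000 nM, and a real chance that the assay again returns only a limit.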

Compound 4, half-maximal inhibitory concentration: 1930 nM
Compound 4: middle estimate off by 5.2-fold (0.71 log units), on the high side; the whole stated range lies above it.
By their numbers in this assay, from the lowest: compounds 4 and 2 (each within the scatter of the next); then compound 3. At a limit, above all of these: compound 1.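

In this assay, within the data shown here, the change from isopentyloxy to methoxy gives the only readable step, an at least 5.1-fold lower number from compound 1 to compound 4 (0.71 log units; beyond the scatter), so the smaller group at this place goes with the lower number, beyond the scatter. The earlier compounds shown here could not show this, as none of them formed a pair differing in one place; this step shows that the group on a saturated chain carbon bound to an oxygen on an aromatic ring can shift the read-out on the shared core. The step has only one pair behind it and its true size stays open on one side, with compound 1 held at a limit: the limit of > 10000 nM in this assay, at which 1 of the 4 values shown sits.

No other steps among the compounds shown can be read, so this single pair does not establish a trend with chain length, and the groups carried by compound 2 and compound 3 cannot be set against methoxy. As far as these compounds go, it also stays open how the read-out would respond at this place to an ethyl or propyl chain between methyl and isopentyl, or to a chain ending in an amine or a carboxylic acid.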